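A few compounds are considered here, and "the series" means these few. Any claim that something is new, unique, unknown or untested is made for them only; others in the source may bear on it.

Compound 2 `C=CC(C)(C)c1[nH]c2ccccc2c1/C=C1\NC(=O)[C@H](C)NC1=O` is a close relative of compound 1 `C=CC(C)(C)c1[nH]c2c(C[C@H](O)C(C)(C)OC)cccc2c1/C=C1\NC(=O)[C@H](C)NC1=O`, which carries a 2-hydroxy-3-methoxy-3-methylbutyl group that compound 2 lacks. In an ADME assay on MDCK cells (Canis lupus familiaris) for cytotoxicity, read by CellTiter-Glo, with a stated time of 40 h (a higher number here means that more compound is tolerated, a lower number that less compound is tolerated), compound 1 gives > 200000 nM, which is a limit of the assay. In this assay compound 2 gives > 200000 nM, again a limit and not a number. The step that the two limits leave unreadable from compound 1 to compound 2 therefore cannot be read, since (the limit of > 200000 nM in this assay, at which 2 of the 2 values shown sit). Compound 3 `C=CC(C)(C)c1[nH]c2ccccc2c1/C=C1\NC(=O)[C@H](CO)NC1=O` differs from compound 2 by hydroxy in place of hydrogen on a saturated chain carbon bound to a saturated ring carbon. Going by the values given here, no measured step bears on this change, so the expected step is a number no higher from compound 2 to compound 3 (the limit leaves the size open), within the scatter. Compound 3 is estimated at 200000 nM, between 100000 nM and 400000 nM.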

Compound 3, half-maximal cytotoxic concentration: > 200000 nM
Compound 3: only a limit was reported; the forecaster's own chance of this, stated with the estimate: 85%; the middle value lies on the limit itself.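

Compound 3 also gives only a limit of the assay, so the step from compound 2 to compound 3 cannot be read: the limit of > 200000 nM in this assay, at which 3 of the 3 values shown sit. Left open is whether compound 1, compound 2 and compound 3 differ at all in this assay.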